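Series notes: formyl to chlorophenylethenyl on the phenol ring

This account rests on a few compounds, and the source may have more. Where it says the series, first, only, none or still open, it means among the compounds named here.

The shared core is set by compound 1 `C=C[C@@](C)(/C=C/c1ccc(O)cc1)CCC1OC1(C)C`, which in a functional assay on SEM cells (Homo sapiens) for cytotoxicity, with a stated time of 72 h (on this read-out higher numbers stand for an effect only at larger amounts of compound and lower numbers for an effect already at smaller amounts), gives > 36600 nM, a limit of the assay and not a number. Compound 2 `C=C[C@@](C)(/C=C/c1ccc(O)cc1)CC/C=C(\C)CO` in this assay likewise gives > 36600 nM, again a limit. The step that the two limits leave unreadable from compound 1 to compound 2 is therefore unreadable, and it concerns the chain end rather than the aromatic ring. For the measured compounds named here, compound 3 `C=C[C@@](C)(/C=C/c1ccc(O)c(C=O)c1)CCC=C(C)C` is the one member with a number: in this assay compound 3 gives 8510 nM. Going by the values given here, it thus stands as the only compound of the three with a read-out inside the window; the other two sit at the limit of > 36600 nM in this assay, at which 2 of the 3 values shown sit.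

Compound 4 `C=C[C@@](C)(/C=C/c1ccc(O)c(/C=C/c2ccc(Cl)cc2)c1)CCC=C(C)C` differs from compound 3 by 2-(4-chlorophenyl)ethenyl in place of formyl on an aromatic carbon. Among the compounds with values here, no measured step bears on this change: the single step between measured compounds lies elsewhere on the molecule and is unreadable. The expectation for compound 4 therefore rests on compound 3 alone, and the step of a 1.4-fold lower number from compound 3 to compound 4 (0.15 log units; within the scatter) is estimated as one that the series cannot size, so no direction beyond the scatter is claimed. Compound 4 is expected to give 6000 nM in this assay, within a wide range from 1500 nM to 25000 nM.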

Compound 4, half-maximal effective concentration: > 36600 nM
Compound 4 ended at the assay's limit (the forecaster's own chance of this, stated with the estimate: 15%); middle value at least 6.1-fold (0.78 log units) from the limit.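

For the compounds shown here, on an aromatic carbon ortho to a hydroxy group and meta to a large group, this assay now gives a first readable step for the series: 2-(4-chlorophenyl)ethenyl in place of formyl gives an at least 4.3-fold higher number from compound 3 to compound 4 (0.63 log units; beyond the scatter). Going by these compounds alone, the only earlier step concerns the chain end and cannot be read, so the earlier compounds showed nothing about how far the read-out depends on the group at this aromatic carbon. Compound 4 now sits at a limit of the assay and not at a number, which leaves compound 3, with formyl, as the only member with a read-out inside the window: the limit of > 36600 nM in this assay, at which 3 of the 4 values shown sit.

Within the data shown here, only two groups at this carbon can be compared, and one of them ends at a limit, so it remains open whether formyl itself matters or whether the larger 2-(4-chlorophenyl)ethenyl is simply not tolerated. A carboxylic acid, an aminomethyl group or a hydroxymethyl group at this carbon, on the chain of compound 3, would test this, and the same carbon bearing only hydrogen would size the contribution of formyl.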